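The compounds below may be only part of what the source reports. "The series", "measured", "known", "first", "only" and "open" are said of these compounds alone.

In a functional assay on MDA-MB-231 cells (Homo sapiens) for cytotoxicity, read by MTT assay, with a stated time of 72 h (a higher number here means that more compound is needed for the effect, a lower number that less compound is needed), compound 1 `CCc1cccc2c(O)c(-c3occ(C)c3C(=O)O)ccc12` gives 0.3 ug/mL. In this assay compound 2 `CCCOC(=O)c1c(C)coc1-c1ccc2c(CC)cccc2c1OC` returns > 10 ug/mL, which is a limit and not a number. Compound 3 `CCc1cccc2c(OC)c(-c3occ(C)c3COCC(F)(F)F)ccc12` keeps the shared core of compound 2 but carries (2,2,2-trifluoroethoxy)methyl in place of propoxycarbonyl on an aromatic carbon of the five-membered aromatic ring: (2,2,2-trifluoroethoxy)methyl in place of propoxycarbonyl on an aromatic carbon. Among the measured compounds shown here, no measured pair of compounds isolates this change, so its size cannot be read directly from the data. The expectation therefore rests on compound 2, whose limit is > 10 ug/mL. The step of a number no higher from compound 2 to compound 3 (the limit leaves the size open) is expected to stay within the usual scatter of this assay, with no clear direction, and the assay may again report only a limit. For compound 3 the estimated value is 10 ug/mL, with an expected range from 3 ug/mL to 30 ug/mL.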

Compound 3, concentration for half-maximal effect: 5.3 ug/mL
Compound 3: middle estimate off by 1.9-fold (0.28 log units), on the high side; the range from low to high includes it.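

Compound 3 gives a number in this assay at this position, on an aromatic carbon of the five-membered aromatic ring, whereas compound 2 gives only a limit. The change from propoxycarbonyl to (2,2,2-trifluoroethoxy)methyl amounts to an at least 1.8-fold lower number from compound 2 to compound 3 (0.27 log units; that floor lies within the scatter), so the step cannot be told from scatter, although the true step may be larger: the limit of > 10 ug/mL in this assay, at which 1 of the 3 values shown sits. The result also shows that a readable number at this position does not depend on a carbonyl, since the entering group has none.

Compound 1 differs from compound 3 in more than one place, so the two cannot be compared, and the effect of each difference stays unresolved. From the compounds shown here alone, how a carboxylic acid or an amine at this position would read on the core of compound 3 remains open.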